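Lengthening the side chain on an aryl vinyl ketone

A few compounds are considered here, and "the series" means these few. Any claim that something is new, unique, unknown or untested is made for them only; others in the source may bear on it.

Of the compounds shown here, three of a shared core have been measured in an in vitro assay on BL21-DE3 cells for displacement of a labelled ligand from thyroid hormone receptor beta (Homo sapiens), read by fluorescence polarization; on this read-out higher numbers stand for weaker inhibition and lower numbers for stronger inhibition. Compound 1 `C/C=C/C(=O)c1ccc(CCCCCCC)cc1` gives 7600 nM, compound 2 `C=C(C)C(=O)c1ccc(CCCCCCC)cc1` gives 23200 nM, and compound 3 `C=CC(=O)c1ccc(CCCC)cc1` gives 66000 nM. Compound 3 therefore stands at the highest number of the three, that is, the weakest inhibition; compound 2 sits nearest to it and compound 1 furthest away. Within the data shown here, the one step among measured compounds that differ in a single place, a 3.1-fold higher number from compound 1 to compound 2 (0.48 log units; beyond the scatter), concerns the group on the carbonyl carbon and does not touch the chain.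

Compound 4 `C=CC(=O)c1ccc(CCCCCCC)cc1` differs from compound 3 by propyl in place of hydrogen on a saturated chain carbon, four bonds along the chain from an aromatic carbon. Among the measured compounds shown here, no measured step covers this change directly. What the numbers do show is that compound 1 and compound 2, both carrying the longer chain, lie at lower numbers than compound 3, which carries the shorter one, while the group on the carbonyl carbon varies as well. On this basis a lower number than compound 3 is expected for compound 4, with a 6.6-fold lower number from compound 3 to compound 4 (0.82 log units; beyond the scatter) estimated as the step. Compound 4 is expected to give about 10000 nM in this assay, within a range from 3000 nM to 30000 nM.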

Compound 4, half-maximal inhibitory concentration: 10500 nM
Estimate against measurement, compound 4: 1.1-fold (0.02 log units) below; the range from low to high includes it.
By their numbers in this assay, from the lowest: compounds 1 and 4 (each within the scatter of the next); then compound 2; then compound 3.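

With vinyl on the carbonyl carbon held fixed, the chain change now has a direct reading in this assay: propyl in place of hydrogen on a saturated chain carbon, four bonds along the chain from an aromatic carbon, gives a 6.3-fold lower number from compound 3 to compound 4 (0.80 log units; beyond the scatter) and so shows that the longer chain alone goes with stronger inhibition in this pair. With the longer chain held fixed instead, the group on the carbonyl carbon gives two different results: removing the methyl, with hydrogen in place of methyl on a double-bonded chain carbon bound to a carbonyl carbon, gives a 2.2-fold lower number from compound 2 to compound 4 (0.34 log units; beyond the scatter), whereas vinyl in place of prop-1-en-1-yl on a carbonyl carbon gives a 1.4-fold higher number from compound 1 to compound 4 (0.14 log units; within the scatter) and so leaves those two compounds indistinguishable. No measurement shown here offers an explanation for these differences.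

Among these compounds, the chain is seen at only two lengths, so it remains open whether a longer chain, or a chain ending in a carboxylic acid or an amine, would lower the number further. Also open, from the compounds shown here alone, is what ethyl on the carbonyl carbon, with no double bond, would give in place of vinyl.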